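Bromo in Place of Methyl on an Aromatic Carbon

This account rests on a few compounds, and the source may have more. Where it says the series, first, only, none or still open, it means among the compounds named here.

In a functional assay on SW1573 cells (Homo sapiens) for inhibition, read by sulforhodamine B assay, with a stated time of 48 h (a higher number here means a weaker inhibitor of growth, a lower number a stronger inhibitor of growth), the two measured compounds gave:
Compound 1 `COC(=O)[C@@]1(C)CC[C@@H]2C3=C1CC[C@@H](C)[C@]3(C)Cc1c2[nH]c2ccccc12`: 8300 nM
Compound 2 `COC(=O)[C@@]1(C)CC[C@@H]2C3=C1CC[C@@H](C)[C@]3(C)Cc1c2[nH]c2c(C)cccc12`: 16000 nM

Going by the values given here, compound 2 stands alongside compound 1, since the only measured step, a 1.9-fold higher number from compound 1 to compound 2 (0.29 log units; within the scatter), lies within the scatter. Compound 3 `COC(=O)[C@@]1(C)CC[C@@H]2C3=C1CC[C@@H](C)[C@]3(C)Cc1c2[nH]c2c(Br)cccc12` differs from compound 2 by bromo in place of methyl on an aromatic carbon. Among the compounds with values here, no measured step exchanges one group for another at this carbon; the single change seen there, hydrogen to methyl, moved this assay little. A small step, a 1.3-fold lower number from compound 2 to compound 3 (0.12 log units; within the scatter), is therefore expected, in no clear direction. Compound 3 is expected to give 12000 nM in this assay, within the range 4000 nM to 40000 nM.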

Compound 3, concentration for 50% growth inhibition: 26000 nM
Compound 3: the middle estimate sits 2.2-fold (0.34 log units) below what was measured, within the range that was stated.
By their numbers in this assay, from the lowest: compounds 1, 2 and 3 (each within the scatter of the next, the first and the last beyond it).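

In this assay bromo in place of methyl gives a 1.6-fold higher number from compound 2 to compound 3 (0.21 log units; within the scatter) and so does not separate these two groups at this carbon. Bromo in place of hydrogen gives a 3.1-fold higher number from compound 1 to compound 3 (0.50 log units; beyond the scatter) and is the first change at this position to pass the scatter, a modest weakening of growth inhibition. No measured information speaks to the reason for this. Whether the position tolerates only such small groups stays open, since an amine, a carboxylic acid or a longer chain on this carbon is not among the compounds shown.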